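Removing One Trifluoromethyl Group: Expected Effect on Cytotoxicity

This account rests on a few compounds, and the source may have more. Where it says the series, first, only, none or still open, it means among the compounds named here.

Measured compounds in a functional assay on MDA-MB-468 cells (Homo sapiens) for inhibition, read by sulforhodamine B assay, with a stated time of 48 h; on this read-out higher numbers stand for lower toxicity in this test and lower numbers for higher toxicity in this test:
compound 1, `COc1cc(-c2nn(-c3cccc(NC(=O)Nc4cc(C(F)(F)F)cc(C(F)(F)F)c4)c3)cc2-c2ccncc2)ccc1Cl`: 24300 nM
compound 2, `COc1cc(-c2nn(-c3cccc(NC(=O)Nc4ccc(Cl)c(Cl)c4)c3)cc2-c2ccncc2)ccc1Cl`: reported only as a limit, > 50000 nM
compound 3, `O=C(Nc1cccc(-n2cc(-c3ccncc3)c(-c3ccc(Cl)c(O)c3)n2)c1)Nc1ccc(Cl)c(Cl)c1`: reported only as a limit, > 32500 nM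

Among the measured compounds shown here, compound 1 carries the only actual number in this assay; the other two values are limits. For the measured compounds named here, the step from compound 2 to compound 3, a step that the two limits leave unreadable from compound 2 to compound 3, cannot be read because both ends are limits, so no measured step bears on the change to compound 4, `COc1cc(-c2nn(-c3cccc(NC(=O)Nc4cccc(C(F)(F)F)c4)c3)cc2-c2ccncc2)ccc1Cl`, which differs from compound 1 by hydrogen in place of trifluoromethyl on an aromatic carbon. Going by the values given here, with no relevant step and one related compound sitting at the limit of > 50000 nM in this assay, at which 1 of the 3 values shown sits, the account expects no change beyond the scatter, with some chance of another limit. For compound 4 the estimate is 35000 nM, between 12000 nM and 100000 nM, an expected step of a 1.4-fold higher number from compound 1 to compound 4 (0.16 log units; within the scatter).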

Compound 4, concentration lethal to 50% of the cells: 50000 nM
Estimate against measurement, compound 4: 1.4-fold (0.15 log units) below, and the stated range covers the measured number.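

In this assay, among the compounds shown here, the change at this aromatic carbon gives the first readable step (a 2.1-fold higher number from compound 1 to compound 4 (0.31 log units; beyond the scatter)), so losing one of the two trifluoromethyl groups moves the number modestly towards lower toxicity in this test. The steps that involve a limit cannot be read (a number no higher from compound 2 to compound 4 (the limit leaves the size open)), so this comparison adds no size. Nothing given here accounts for the step. From the compounds shown here alone, it remains open whether an amine or a carboxylic acid on this carbon would shift the number in the same direction.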